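Chloro for ethyl beside the carboxymethoxy group

The compounds below may be only part of what the source reports. "The series", "measured", "known", "first", "only" and "open" are said of these compounds alone.

The series shares a core seen in compound 1 `Cc1cc(OCCCS(C)(=O)=O)cc(C)c1-c1cccc(COc2ccc(OCC(=O)O)cc2)c1`. In a functional assay on CHO cells for agonist activity at Free fatty acid receptor 1 (Homo sapiens), read by fluorescence and calcium flux (a higher number here means that more compound is needed for the effect, a lower number that less compound is needed), compound 1 gives 121 nM. Compound 2 `CCc1cc(OCc2cccc(-c3c(C)cc(OCCCS(C)(=O)=O)cc3C)c2)ccc1OCC(=O)O` carries an ethyl group on the ring that bears the carboxymethoxy group; for compound 2 the outcome in this assay is "not determined" (no result reported), so no single number fixes where compound 2 stands, and the only measured anchor in the set remains compound 1.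

Compound 3 `Cc1cc(OCCCS(C)(=O)=O)cc(C)c1-c1cccc(COc2ccc(OCC(=O)O)c(Cl)c2)c1` is the next member, still to be measured in this assay. Relative to compound 2, the change is chloro in place of ethyl on an aromatic carbon, ortho to a carboxymethoxy group and meta to a large group. Among the compounds with values here, no measured pair in the set reports a step of this kind, so the size and direction of the effect in this assay cannot be read from the data; a shift within the scatter, or a small one in either direction, is the working expectation.

Compound 3 is expected to give about 100 nM in this assay, estimated within 35 nM to 300 nM, resting on the value of compound 1 at 121 nM as the nearest measured point.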

Compound 3, half-maximal effective concentration: 92.6 nM
For compound 3 the middle estimate is 1.1-fold (0.03 log units) above the measured one; measured number inside the range.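

In this assay the set now has its first readable step at this position: chloro in place of hydrogen on the aromatic carbon ortho to a carboxymethoxy group gives a 1.3-fold lower number from compound 1 to compound 3 (0.12 log units; within the scatter), so on this measure the chloro compound cannot be told apart from the unsubstituted compound. Going by these compounds, the direct exchange of ethyl for chloro cannot be read, as compound 2 has no reported result, and the effect of ethyl on this carbon remains unknown. Nothing measured on these compounds speaks to what lies behind this outcome.

Open, on these data alone, is whether a fluoro, a methoxy or a trifluoromethyl group on this same carbon would also stay within the scatter of compound 1, or would move the number beyond it. Also open, as far as these compounds go, is whether the chloro step would hold if the carboxymethoxy group gave way to a longer acid chain or an amide.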